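From compound 3 to compound 4: a phenyl added

The source may hold more compounds than are shown below. What is called first, only, known or untested is meant among the compounds shown, and "the series" means these compounds.

Compound 1 `CC(=O)N[C@@H](CO)[C@H](O)/C=C/c1ccccc1`: no result reported
Compound 2 `CCCCCCCCc1ccc(/C=C/C(=O)[C@H](CO)NC(C)=O)cc1`: 65000 nM
Compound 3 `CC(=O)N[C@@H](CO)C(=O)/C=C/c1ccccc1`: > 200000 nM
Compound 4 `CC(=O)N[C@@H](CO)C(=O)/C=C/c1ccc(-c2ccccc2)cc1`: not yet measured

In a functional assay on HepG2 cells (Homo sapiens) for antiproliferative activity, read by resazurin assay, with a stated time of 24 h (on this read-out lower numbers stand for stronger inhibition and higher numbers for weaker inhibition), compound 3 gives > 200000 nM, and this is a limit of the assay, not a number. Among the measured compounds shown here, compound 3 therefore has no exact place on the scale, and it is the only compound in this small set that stands at such a limit (the limit of > 200000 nM in this assay, at which 1 of the 3 values shown sits).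

The change to compound 4 is phenyl in place of hydrogen on an aromatic carbon, para to a large group. For the measured compounds named here, one measured step bears on it, and it runs the other way, with hydrogen in place of octyl on an aromatic carbon: an at least 3.0-fold higher number from compound 2 to compound 3 (0.48 log units; beyond the scatter). Read backwards, this step means that a large group on the aromatic carbon goes with the lower number, as compound 2 shows with 65000 nM. Phenyl is not octyl, and this is a single pair, so only a modest move toward a lower number in this assay is expected, and compound 4 may yet stay at the limit. The expected step is an at least 1.8-fold lower number from compound 3 to compound 4 (0.25 log units; that floor lies within the scatter). For compound 4 the estimated value is 110000 nM, with an expected range from 45000 nM to 200000 nM.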

Compound 4, half-maximal inhibitory concentration: 41000 nM
For compound 4 the middle estimate is 2.7-fold (0.43 log units) above the measured one; the measured number lies below the stated range.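

In this assay, phenyl in place of hydrogen on the aromatic carbon, para to a large group, gives an at least 4.8-fold lower number from compound 3 to compound 4 (0.68 log units; beyond the scatter), so a ring at this place, like the octyl chain before it, goes with a value that can be read on the scale. The value of compound 3, > 200000 nM, is a limit and not a number, so this step has a floor but no known size: the limit of > 200000 nM in this assay, at which 1 of the 4 values shown sits.

Octyl and phenyl cannot be told apart at this place in this assay, with a 1.6-fold lower number from compound 2 to compound 4 (0.20 log units; within the scatter), so a straight chain and an aromatic ring serve about equally here, and the two compounds together give the only readings on the scale in this small set.

The compounds shown leave open whether any group larger than hydrogen would do at this place, or whether a small group such as methyl, or one carrying an amine or a carboxylic acid, would give a different number. Also open, on these data alone, is whether a chain longer than octyl would move the number beyond the values of compound 2 and compound 4.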